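Amide variation on a shared core: cell toxicity

This account rests on a few compounds, and the source may have more. Where it says the series, first, only, none or still open, it means among the compounds named here.

Measured compounds:
compound 1 `CCCC(=O)Nc1ncc(-c2ccc(OC)cc2)n1C` — > 100000 nM
compound 2 `COc1ccc(-c2cnc(NC(=O)c3cccc([N+](=O)[O-])c3)n2C)cc1` — > 100000 nM
compound 3 `COc1ccc(-c2cnc(NC(=O)c3ccccc3C)n2C)cc1` — > 100000 nM

In a toxicity assay on THP-1 cells (Homo sapiens) for inhibition (on this read-out lower numbers stand for higher toxicity in this test and higher numbers for lower toxicity in this test), compound 1 gives > 100000 nM, which is a limit of the assay and not a number. Compound 2 gives > 100000 nM, again a limit. Compound 3 gives > 100000 nM, also a limit. All three values sit at the limit of > 100000 nM in this assay, at which 3 of the 3 values shown sit, so compound 3 stands at the limit together with the other two, and the step that the two limits leave unreadable from compound 1 to compound 3 cannot be read because both of its ends are limits.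

Compound 4 `COc1ccc(-c2cnc(NC(=O)c3cccc(F)c3)n2C)cc1` differs from compound 3 by 3-fluorophenyl in place of 2-methylphenyl on a carbonyl carbon. Among the measured compounds shown here, no measured step concerns this change; the only single-place step known, a step that the two limits leave unreadable from compound 1 to compound 3, is unreadable and concerns a different group on the same carbonyl carbon. There is therefore no basis in this assay for expecting a step beyond the scatter in either direction.

Compound 4 is expected at 100000 nM, with a range from 40000 nM to 300000 nM, most probably reported as a limit once more. The step of a number no higher from compound 3 to compound 4 (the limit leaves the size open) is the estimated consequence, because compound 3 gives > 100000 nM and that limit is taken as the starting point.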

Compound 4, half-maximal cytotoxic concentration: > 100000 nM
Compound 4 ended at the assay's limit; the forecaster's own chance of this, stated with the estimate: 85%; the middle value lies on the limit itself.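

In this assay compound 4 gives > 100000 nM, a limit and not a number. No new step can be read from compound 1, compound 2 or compound 3 to compound 4, with every value at the same limit: the limit of > 100000 nM in this assay, at which 4 of the 4 values shown sit.

From the compounds shown here alone, whether any amide group on the shared core gives a measurable toxicity value stays open.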